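The source may report more compounds than this note shows. Statements on the series, on what has been measured and on what is new or still open speak of the compounds shown alone.

Measured compounds in a functional assay on HeLa cells (Homo sapiens) for inhibition, read by sulforhodamine B assay; a lower number here means a stronger inhibitor, a higher number a weaker inhibitor:
- compound 1, `O=C1C(Nc2cccc(Cl)c2)=CC(=O)c2c1nc1n2[C@H]2OC[C@@H](O)[C@H]2OC1`: 7970 nM
- compound 2, `O=C1C=C(NC2CCCC2)C(=O)c2c1nc1n2[C@H]2OC[C@@H](O)[C@H]2OC1`: the result for compound 2 is a limit of this assay, > 16000 nM
- compound 3, `COc1ccc(NC2=CC(=O)c3nc4n(c3C2=O)[C@H]2OC[C@@H](O)[C@H]2OC4)cc1`: 4780 nM

Compound 1 has the highest of the two numbers; the nearest is compound 3, which sits within the scatter of compound 1. Compound 2 stands apart, its result being only a limit, as noted in the limit of > 16000 nM in this assay, at which 1 of the 3 values shown sits.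

Within the data shown here, the one measured step that involves a change on the amine nitrogen is an at least 3.3-fold lower number from compound 2 to compound 3 (0.52 log units; beyond the scatter), where an aromatic group in place of a saturated ring lowered the number beyond the scatter.

Compound 4, `O=C1C(NCc2ccccc2)=CC(=O)c2c1nc1n2[C@H]2OC[C@@H](O)[C@H]2OC1`, is to be measured. It differs from compound 1 by benzyl in place of 3-chlorophenyl on an amine nitrogen. The benzyl group keeps the aromatic ring of compound 1 but moves it one carbon away from the amine nitrogen, so it stands between the aryl amine of compound 1 and the alkyl amine of compound 2. Among the measured compounds shown here, no measured step covers exactly this change; the step from compound 2 to compound 3 points to a higher number when the aryl group leaves the nitrogen. A rise beyond the scatter is therefore expected in this assay, though smaller than for compound 2, with a fair chance that only a limit is returned.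

Compound 4 is expected to give 13000 nM, within 5000 nM to 30000 nM. The expected step is a 1.6-fold higher number from compound 1 to compound 4 (0.21 log units; within the scatter).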

Compound 4, half-maximal inhibitory concentration: 11000 nM
Compound 4: middle estimate off by 1.2-fold (0.07 log units), on the high side; measured number inside the range.
By their numbers in this assay, from the lowest: compounds 3, 1 and 4 (each within the scatter of the next, the first and the last beyond it). At a limit, above all of these: compound 2.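

Benzyl in place of 3-chlorophenyl on the amine nitrogen gives a 1.4-fold higher number from compound 1 to compound 4 (0.14 log units; within the scatter) in this assay, so this change leaves the result within the scatter of compound 1, even though the aromatic ring now stands one carbon further from that nitrogen. Compound 4 returns a number, so among these compounds an aromatic ring need not sit directly on the amine nitrogen for a number to be read, although this single step cannot separate the loss of the chlorine from the added carbon. Compound 2, with cyclopentyl, remains the only result that is a limit: the limit of > 16000 nM in this assay, at which 1 of the 4 values shown sits.

Still open, on these data alone, is how unsubstituted phenyl, 3-chlorobenzyl and 2-phenylethyl on the amine nitrogen would compare, and these three would show whether the chlorine or the carbon link matters on its own. Also open, as far as these compounds go, is whether a group such as a carboxylic acid or a dimethylamino group on the aromatic ring would move the number in this assay beyond the scatter of compound 1 and compound 4.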